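The source may report more compounds than this note shows. Statements on the series, on what has been measured and on what is new or still open speak of the compounds shown alone.

Measured compounds in an ADME assay on BJ cells (Homo sapiens) for cytotoxicity, read by luminescence, with a stated time of 72 h; on this read-out higher numbers stand for an effect only at larger amounts of compound and lower numbers for an effect already at smaller amounts:
compound 1, `CCOC(=O)c1c(-c2cccc(-c3ccccc3)c2)[nH]c2cc(OC)c(F)cc2c1=O`: > 21500 nM, a limit of the assay rather than a number
compound 2, `CCOC(=O)c1c(-c2cccc(OC(F)(F)F)c2)[nH]c2cc(OC)c(F)cc2c1=O`: > 21500 nM, likewise a limit of the assay rather than a number

Within the data shown here, compound 2 therefore stands at the edge of what this assay reports: its value is a limit, and the one further value shown is a limit as well, so no ordering between the two can be read. Among the measured compounds shown here, the single measured step, a step that the two limits leave unreadable from compound 1 to compound 2, has no readable size, since the limit of > 21500 nM in this assay, at which 2 of the 2 values shown sit, places both values at the same limit.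

Compound 3, `CCOC(=O)c1c(-c2cccc(Br)c2)[nH]c2cc(OC)c(F)cc2c1=O`, differs from compound 2 by bromo in place of trifluoromethoxy on an aromatic carbon. No measured step with a readable size bears on this change; the only step shown gives no size at all.

Because the limit of > 21500 nM in this assay, at which 2 of the 2 values shown sit, holds both measured values at the limit, compound 3 is expected to sit at or near that limit as well, with an estimated value of 30000 nM, ranging from 15000 nM to 80000 nM. The step this estimate implies, a step that the limit leaves unreadable from compound 2 to compound 3, is expected to stay within the scatter, though with both known values being limits this remains an estimate only.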

Compound 3, half-maximal effective concentration: > 21500 nM
Compound 3: no number, only a limit; the forecaster's own chance of this, stated with the estimate: 80%; the middle value lies beyond the limit too.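

In this assay compound 3 gives > 21500 nM as a limit of the assay and not a number. Among these compounds, no step among compound 1, compound 2 and compound 3 can be read, because all their values coincide at one limit: the limit of > 21500 nM in this assay, at which 3 of the 3 values shown sit.

The compounds shown leave open whether phenyl, trifluoromethoxy and bromo differ at all in this assay once a measurable value is reached.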